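This account rests on a few compounds, and the source may have more. Where it says the series, first, only, none or still open, it means among the compounds named here.

Two compounds share one core and differ only in the group carried on an amine nitrogen. Compound 1, `COc1cc(Oc2cccc(Nc3ccccc3)c2)cc(OC)c1CNCc1ccc(C)cc1`, carries a 4-methylbenzyl group there, and in a functional assay on HT-29 cells (Homo sapiens) for inhibition, read by MTT assay, with a stated time of 72 h (on this read-out lower numbers stand for stronger inhibition and higher numbers for weaker inhibition), compound 1 gives 3880 nM. Compound 2, `COc1cc(Oc2cccc(Nc3ccccc3)c2)cc(OC)c1CNC(C)C`, carries an isopropyl group in the same place. In this assay compound 2 gives > 20000 nM, which is a limit of the assay rather than a measured number, so compound 2 stands at the weak end of what this assay can report (the limit of > 20000 nM in this assay, at which 1 of the 2 values shown sits). The step between them is an at least 5.1-fold higher number from compound 1 to compound 2 (0.71 log units; beyond the scatter), so exchanging the benzyl-type group for the small branched chain cost clearly more than ordinary scatter.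

Compound 3, `COc1cc(Oc2cccc(Nc3ccccc3)c2)cc(OC)c1CNCc1ccc(O)cc1`, is not yet measured. Relative to compound 2 its change is 4-hydroxybenzyl in place of isopropyl on an amine nitrogen. This largely undoes the change seen in the step from compound 1 to compound 2, restoring a benzyl-type group to the nitrogen, though now with a hydroxyl on the ring instead of a methyl. Because an at least 5.1-fold higher number from compound 1 to compound 2 (0.71 log units; beyond the scatter) was a loss on removing the benzyl group, a gain of comparable size is expected on putting one back, giving an at least 4.0-fold lower number from compound 2 to compound 3 (0.60 log units; beyond the scatter). Compound 3 is therefore expected to give roughly 5000 nM, most likely between 1500 nM and 20000 nM in this assay.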

Compound 3, half-maximal inhibitory concentration: 2180 nM
Compound 3: the middle estimate sits 2.3-fold (0.36 log units) above what was measured; the measured number falls inside the stated range.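

In this assay, 4-hydroxybenzyl in place of isopropyl on the amine nitrogen gives an at least 9.1-fold lower number from compound 2 to compound 3 (0.96 log units; beyond the scatter), so the advantage over isopropyl is not confined to the 4-methylbenzyl group of compound 1. What the ring carries matters little in this pair: hydroxy in place of methyl on an aromatic carbon gives a 1.8-fold lower number from compound 1 to compound 3 (0.25 log units; within the scatter), which leaves compound 1 and compound 3 indistinguishable in this assay, even though the two groups differ in kind. The step to compound 3 gives only a minimum for the gain, not its exact size: the limit of > 20000 nM in this assay, at which 1 of the 3 values shown sits.

Still open, on these data alone, is whether the aromatic ring on the nitrogen is itself required, or whether a saturated cyclohexylmethyl group or a longer straight chain would serve equally well. It is also unknown how far the ring tolerates other substituents, for example a carboxylic acid or an amine in place of the hydroxyl, and whether any of them would give a number clearly lower than those of compound 1 and compound 3.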